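Cyclopentyloxy in place of methoxy on compound 2

The source may report more compounds than this note shows. Statements on the series, on what has been measured and on what is new or still open speak of the compounds shown alone.

Compound 2 `COc1ccc(/C=C2\NC(=O)N(CCCN3CCN(c4ncccn4)CC3)C2=O)cc1OC` gives 74 nM in an assay on CHO cells for displacement of a labelled ligand from 5-hydroxytryptamine receptor 7 (Homo sapiens), read by scintillation counting, with a stated time of 60 min (a lower number here means a stronger inhibitor, a higher number a weaker inhibitor), the higher of the two numbers measured. Among the measured compounds shown here, compound 1 `COc1ccc(/C=C2\NC(=O)N(CCCN3CCN(c4cccc(Cl)c4Cl)CC3)C2=O)cc1OC` gives 22 nM, and a 3.4-fold higher number from compound 1 to compound 2 (0.53 log units; beyond the scatter) is the only measured step. Compound 3 `COc1ccc(/C=C2\NC(=O)N(CCCN3CCN(c4ncccn4)CC3)C2=O)cc1OC1CCCC1` differs from compound 2 by cyclopentyl in place of methyl on an oxygen on an aromatic ring. For the measured compounds named here, no measured step concerns that oxygen; the one step known lies at the amine nitrogen in a ring and gives no guidance here. The step from this change is expected to be a 1.1-fold lower number from compound 2 to compound 3 (0.02 log units; within the scatter), not beyond the scatter. Compound 3 is estimated at 70 nM, with a range from 20 nM to 250 nM.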

Compound 3, inhibition constant: > 1000 nM
Compound 3 gave a limit, no number; the forecaster's own chance of this, stated with the estimate: 5%; at least 14-fold (1.15 log units) between middle value and limit.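

In this assay, the oxygen on the aromatic ring proves far from neutral: methoxy to cyclopentyloxy gives an at least 13-fold higher number from compound 2 to compound 3 (1.13 log units; beyond the scatter), a large step against the modest one at the amine nitrogen in a ring. On these data alone, compound 3 stands at a limit, not a number, so the true size of the step stays unknown: the limit of > 1000 nM in this assay, at which 1 of the 3 values shown sits.

Open, as far as these compounds go, is whether an ethyl or a straight pentyl chain on this oxygen would read like methyl or like cyclopentyl. Also open, from the compounds shown here alone, is whether the same change on compound 1 carries a similar penalty.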